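Fluoro-for-hydrogen step in the oxime ether series

The source may hold more compounds than are shown below. What is called first, only, known or untested is meant among the compounds shown, and "the series" means these compounds.

Measured compounds:
compound 1 `O=c1c(OC/C(=N/O)c2ccccc2)c(-c2ccccc2)oc2ccccc12` — 7210000 nM
compound 2 `O=c1c(OC/C(=N/O)c2ccc(F)cc2)c(-c2ccccc2)oc2ccccc12` — 6900000 nM
compound 3 `CO/N=C(/COc1c(-c2ccccc2)oc2ccccc2c1=O)c1ccccc1` — 7110000 nM

Notes. All three compounds share one core and are read in a functional assay on SK-HEP1 cells (Homo sapiens) for antiproliferative activity; on this read-out higher numbers stand for weaker inhibition of growth and lower numbers for stronger inhibition of growth. Compound 3 gives 7110000 nM, the second highest of the three numbers; its nearest neighbour is compound 1, and all three values sit within the usual scatter of one another, so no order among them can be stated.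

Compound 4 `CO/N=C(/COc1c(-c2ccccc2)oc2ccccc2c1=O)c1ccc(F)cc1` is the next member, not yet measured. Against compound 3 the change is fluoro in place of hydrogen on an aromatic carbon. The same change has already been made once within the series, from compound 1 to compound 2, where the result was a 1.0-fold lower number from compound 1 to compound 2 (0.02 log units; within the scatter). The methyl-for-hydrogen step, a 1.0-fold lower number from compound 1 to compound 3 (0.01 log units; within the scatter), likewise moved nothing beyond the scatter. On that basis no shift beyond the scatter is expected in this assay for compound 4; the expected step is a 1.0-fold lower number from compound 3 to compound 4 (0.01 log units; within the scatter). The estimate for compound 4 is therefore 7000000 nM, with a range of 3500000 nM to 14000000 nM.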

Compound 4, concentration for 50% growth inhibition: 13000000 nM
The estimate for compound 4 lay 1.9-fold (0.27 log units) below the measured number; the measured number falls inside the stated range.
By their numbers in this assay, from the lowest: compounds 2, 3, 1 and 4 (each within the scatter of the next).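

In this assay, the phenyl to 4-fluorophenyl change, now read on a second core, gives a 1.8-fold higher number from compound 3 to compound 4 (0.26 log units; within the scatter), and the two readings of this change do not separate: the same change on two cores in this assay, a 1.0-fold lower number (0.02 log units; within the scatter) from compound 1 to compound 2 and a 1.8-fold higher number (0.26 log units; within the scatter) from compound 3 to compound 4, 1.9-fold (0.28 log units) apart, within the scatter of two such steps. With the fluoro group in place, methyl in place of hydrogen on an oxygen gives a 1.9-fold higher number from compound 2 to compound 4 (0.28 log units; within the scatter), and the two readings of that change do not separate either: the same change on two cores in this assay, a 1.0-fold lower number (0.01 log units; within the scatter) from compound 1 to compound 3 and a 1.9-fold higher number (0.28 log units; within the scatter) from compound 2 to compound 4, 1.9-fold (0.28 log units) apart, within the scatter of two such steps. Neither change is therefore shown to depend on the other, and the four compounds still admit no firm order.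

The compounds shown leave open whether any change at these two places can move the number beyond the scatter. An amine or a carboxylic acid in place of the fluoro group, or a longer chain in place of the methyl on the oxygen, would address this.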